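A few compounds are considered here, and "the series" means these few. Any claim that something is new, unique, unknown or untested is made for them only; others in the source may bear on it.

Among the measured compounds shown here, compound 1 `CCn1c(SCC(=O)Nc2ccc(/C(C)=N/O)cc2)nnc1-c1cc(OC)c(OC)c(OC)c1` and compound 2 `C=CCn1c(SCC(=O)Nc2ccc(/C(C)=N/O)cc2)nnc1-c1ccc(OC)c(OC)c1` share a common core but differ from each other in two places at once, so no single step is counted between them. In a functional assay on the whole organism (strain albino) for inhibition, with Rattus norvegicus as the target, read by paw edema, with stated times of 30 min and 3 h, at a dose of 0.28 mmol/kg by the oral route (a lower number here means less inhibition, a higher number more inhibition at the dose given (going by the name of the read-out)), compound 1 gives 70%, and in this assay compound 2 gives 70%, the same reading at the digits reported and within the usual scatter of this measurement. Compound 2 therefore stands at the same level as compound 1, with nothing to separate the two.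

Compound 3 `C=CCn1c(SCC(=O)Nc2ccc(/C(C)=N/O)cc2)nnc1-c1cc(OC)c(OC)c(OC)c1` follows from compound 2 by a single change: methoxy in place of hydrogen on an aromatic carbon. Compound 3 thus carries the same substitution on that aromatic ring as compound 1 while otherwise matching compound 2. With compound 1 at 70% and compound 2 at 70% in this assay, the step from compound 2 to compound 3 is expected to be small, no change at the digits printed from compound 2 to compound 3 (within the scatter), with no direction beyond the scatter. Compound 3 is expected to give 70% in this assay, within a range from 58% to 80%.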

Compound 3, a percentage reported as inhibition, in the whole organism at one dose (the size of the read-out at that dose, not a potency): 62%
Estimate against measurement, compound 3: 8 percentage points above; low and high end bracket the measured number.
By their numbers in this assay, from the lowest: compounds 3, 1 and 2 (each within the scatter of the next).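

At the aromatic carbon that lies ortho to a methoxy group and meta to a large group, methoxy in place of hydrogen gives a number 8 percentage points lower from compound 2 to compound 3 (within the scatter) in this assay, so at this single dose this position accepts the added methoxy without a reading that can be told from the scatter. The chain on the aromatic nitrogen can now also be read on its own: vinyl in place of methyl on the saturated chain carbon gives a number 8 percentage points lower from compound 1 to compound 3 (within the scatter), likewise no separable difference. No measurement here speaks to why these readings stay so close.

What the compounds shown leave open is how this aromatic position responds to a group other than methoxy, such as an ethoxy, a chlorine or an amine. They also leave open how a longer chain, such as butyl, on the aromatic nitrogen would read in this assay.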